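Swapping trifluoromethyl for pyridin-2-yl on compound 3

A few compounds are considered here, and "the series" means these few. Any claim that something is new, unique, unknown or untested is made for them only; others in the source may bear on it.

In an ADME assay (liver) for pharmacokinetics, with Liver microsome (Rattus norvegicus) as the target, read by LC-MS, using microsomes, tested at 2 uM (a lower number here means slower removal, a higher number faster removal of the compound), compound 1 `Cc1c(C(=O)N[C@@H]2CCCC[C@H]2O)cc(-c2cc(C(F)(F)F)ccc2Cl)n1CC1CCCCC1` gives 1.32 mL/min/kg, compound 2 `O=C(N[C@@H]1CCCC[C@H]1O)c1cnc(OC2CCCC2)c(-c2cc(C(F)(F)F)ccc2Cl)c1` gives 0.367 mL/min/kg, and compound 3 `O=C(N[C@@H]1CCCC[C@H]1O)c1cnc(OCC(F)(F)F)c(-c2ccc(Cl)cc2)c1` gives 0.023 mL/min/kg, the lowest of the three and beyond the scatter from both others. Compound 4 `O=C(N[C@@H]1CCCC[C@H]1O)c1cnc(OCc2ccccn2)c(-c2ccc(Cl)cc2)c1` keeps the core of compound 3 but carries pyridin-2-yl in place of trifluoromethyl on a saturated chain carbon bound to an oxygen on an aromatic ring. Going by the values given here, no measured pair shows this change, so its size is a judgement. Compound 3 sits so low, at 0.023 mL/min/kg, that a rise beyond the scatter in this assay seems likelier than a fall. The expected step is an 11-fold higher number from compound 3 to compound 4 (1.04 log units; beyond the scatter). For compound 4 the estimate is 0.25 mL/min/kg, with an expected range from 0.05 mL/min/kg to 1.3 mL/min/kg.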

Compound 4, clearance: 0.044 mL/min/kg
Estimate against measurement, compound 4: 5.7-fold (0.75 log units) above; measured number outside the range, below it.
By their numbers in this assay, from the lowest: compounds 3 and 4 (each within the scatter of the next); then compound 2; then compound 1.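

In this assay the swap gives a 1.9-fold higher number from compound 3 to compound 4 (0.28 log units; within the scatter) at this place, a step within the scatter. On this core, then, the fluorine atoms of trifluoromethyl are not needed to keep the number low, since pyridin-2-yl, a larger group with an aromatic ring, serves as well. No measurement shown bears on the reason for this.

An amine or a carboxylic acid at this place might or might not keep the number as low. From the compounds shown here alone, whether pyridin-2-yl would do the same on the core of compound 2 also remains open.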